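Removing one guanidine from a bis-guanidine diaryl ester

A few compounds are considered here, and "the series" means these few. Any claim that something is new, unique, unknown or untested is made for them only; others in the source may bear on it.

Compound 1 `N=C(N)Nc1ccc(OC(=O)c2ccc(NC(=N)N)cc2)cc1` is the starting point. Among the measured compounds shown here, in an assay on isolated protein for inhibition of Trypsin (Homo sapiens), read by fluorescence, with a stated time of 15 min, tested at 50 uM (on this read-out higher numbers stand for more inhibition at the one concentration tested (going by the name of the read-out) and lower numbers for less inhibition), compound 1 gives 100%, and of the two numbers measured so far its value is indistinguishable from that of compound 2 `N=C(N)Nc1ccc(OC(=O)c2ccc(N)cc2)cc1`, which in this assay gives 101%; the step of a number 1 percentage points higher from compound 1 to compound 2 (within the scatter) lies within the scatter. The unmeasured compound 3 `N=C(N)Nc1ccc(C(=O)Oc2ccc(N)cc2)cc1` differs from compound 1 in this way: a hydrogen atom in place of a group of 3 heavy atoms (1 carbon, 2 nitrogen; no ring), on a nitrogen on an aromatic ring. The same kind of change, a guanidine on an aromatic nitrogen replaced by hydrogen, is the one already seen in the step from compound 1 to compound 2, which moved the number by only a number 1 percentage points higher from compound 1 to compound 2 (within the scatter). That single measured step therefore bears directly on the present one, and it was small. For compound 3 no shift beyond the scatter is expected in this assay, a step estimated at no change at the digits printed from compound 1 to compound 3 (within the scatter). Compound 3 is thus expected to give about 100%, within a range of 85% to 105%.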

Compound 3, a percentage reported as inhibition, at one concentration (the size of the read-out at that concentration, not a potency): 103%
Estimate against measurement, compound 3: 3 percentage points below; the measured number falls inside the stated range.
By their numbers in this assay, from the lowest: compounds 1, 2 and 3 (each within the scatter of the next).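

The step of a number 3 percentage points higher from compound 1 to compound 3 (within the scatter) shows that in this assay the other guanidine of compound 1 can also give way to a hydrogen atom on its aromatic nitrogen, with no shift beyond the scatter. Compound 2 keeps the guanidine that compound 3 loses, so each guanidine of compound 1 has now been replaced singly, and neither one alone is needed for the reading at this single concentration. Nothing available accounts for this result.

A reading at one concentration is not a potency, so any differences in potency among these compounds remain unknown. Also open, as far as these compounds go, is whether the number would hold with an amine at both ends and no guanidine left, or with an amide in place of the ester.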